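Swapping the aryl group of compound 3 for a fluorinated ring

This account rests on a few compounds, and the source may have more. Where it says the series, first, only, none or still open, it means among the compounds named here.

This account follows three measured compounds and one that awaits measurement in a functional assay on the whole organism (strain Swiss albino) for inhibition, with Mus musculus as the target, in the formalin test, with stated times of 30 min and 5 min, at a dose of 100 mg/kg; on this read-out higher numbers stand for more inhibition at the one dose given (going by the name of the read-out) and lower numbers for less inhibition. Compound 1 `CCN1CCc2c(c(C)nn2C(=O)Nc2cc(C)ccc2F)C1` gives 5.2% in this assay. Compound 2 `CCN1CCc2c(c(C(C)(C)C)nn2C(=O)Nc2cc(C)ccc2C)C1` gives 0%. Compound 3 `CCN1CCc2c(c(C(C)(C)C)nn2C(=O)Nc2ccc(C)cc2C)C1` gives 15.7%, the highest of the three numbers, with compound 1 the nearest and compound 2 the furthest below it.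

Among the compounds with values here, the one measured step within the set is a number 15.7 percentage points higher from compound 2 to compound 3 (beyond the scatter), so a change on the aryl group attached to the amide-type nitrogen has already moved the number by a modest amount in this assay.

Compound 4 `CCN1CCc2c(c(C(C)(C)C)nn2C(=O)Nc2cc(C)ccc2F)C1` differs from compound 3 in one place: 2-fluoro-5-methylphenyl in place of 2,4-dimethylphenyl on an amide-type nitrogen. Compound 1 carries the same 2-fluoro-5-methylphenyl group as compound 4 on the amide-type nitrogen, and its value in this assay is low, while compound 3 with 2,4-dimethylphenyl is the highest measured. Since the aryl change from compound 2 to compound 3 was worth a modest step, and compound 1 with the entering group gives 5.2%, a modest step downward is expected here: a number 10.7 percentage points lower from compound 3 to compound 4 (beyond the scatter). Compound 4 is therefore estimated to give 5% in this assay, within a range from 0% to 15%.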

Compound 4, a percentage reported as inhibition, in the whole organism at one dose (the size of the read-out at that dose, not a potency): 7%
Estimate against measurement, compound 4: 2 percentage points below; the measured number falls inside the stated range.
By their numbers in this assay, from the lowest: compounds 2, 1, 4 and 3 (each within the scatter of the next, the first and the last beyond it).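

In this assay the exchange at this position, 2-fluoro-5-methylphenyl in place of 2,4-dimethylphenyl on the amide-type nitrogen, gives a number 8.7 percentage points lower from compound 3 to compound 4 (within the scatter) and so cannot be told apart from repeated measurement, whereas the earlier aryl change gave a number 15.7 percentage points higher from compound 2 to compound 3 (beyond the scatter) and could. Within the data shown here, compound 4 also isolates two single exchanges that the earlier compounds could not show: fluoro in place of methyl on an aromatic carbon gives a number 7 percentage points higher from compound 2 to compound 4 (within the scatter) and tert-butyl in place of methyl on an aromatic carbon gives a number 1.8 percentage points higher from compound 1 to compound 4 (within the scatter) in this assay with neither exchange separating its pair. Among these four compounds, then, only compound 2 and compound 3 stand apart, and the fluoro-bearing ring neither clearly keeps nor clearly loses what compound 3 shows.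

The compounds shown leave open whether a chloro or methoxy group on the aryl ring, or a cyclohexyl group in place of that ring on the amide-type nitrogen, would give a number clearly higher than that of compound 3 in this assay at this single dose. No measurement at hand offers any explanation for these numbers.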